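From dimethylamino to 4-methylpiperazin-1-yl in compound 1

The source may report more compounds than this note shows. Statements on the series, on what has been measured and on what is new or still open speak of the compounds shown alone.

In an ADME assay on a cell-free system (plasma, Rattus norvegicus) for protein binding, compound 1 `CNc1nccc(N2CC[C@H](NC(=O)Nc3ccc(CN(C)C)c(C(F)(F)F)c3)C2)n1` gives 91% while compound 2 `CCNc1nccc(N2CC[C@H](NC(=O)Nc3ccc(Cl)c(C(F)(F)F)c3)C2)n1` gives 99.9% as its reading. Compound 1 thus has the higher unbound fraction of the two, and the gap lies beyond the scatter. The change 4-methylpiperazin-1-yl in place of dimethylamino on a saturated chain carbon bound to an aromatic carbon leads to compound 3 `CNc1nccc(N2CC[C@H](NC(=O)Nc3ccc(CN4CCN(C)CC4)c(C(F)(F)F)c3)C2)n1` and puts 4-methylpiperazin-1-yl in place of dimethylamino on a saturated chain carbon bound to an aromatic carbon. Going by the values given here, no measured pair shows this change, so the expectation starts from compound 1 at 91% alone. A small step a 1.3-fold lower unbound fraction from compound 1 to compound 3 (0.11 log units; within the scatter) is expected, toward more binding and within the scatter. Compound 3 is estimated at 93% with a range from 85% to 98% expected.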

Compound 3, plasma protein binding: 85.1%
For compound 3 the middle estimate is 2.1-fold (0.33 log units) (unbound fraction) below the measured one, within the range that was stated.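

In this assay, the exchange gives a 1.7-fold higher unbound fraction from compound 1 to compound 3 (0.22 log units; within the scatter). At this saturated chain carbon bound to an aromatic carbon, the larger 4-methylpiperazin-1-yl, with its six-membered non-aromatic ring, thus replaces dimethylamino without a step beyond the scatter. Nothing shown explains this outcome. The compounds leave open how a morpholine ring or a carboxylic acid at the same place would read in this assay. They also leave open whether this result would hold for other amines at that carbon.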